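A few compounds are considered here, and "the series" means these few. Any claim that something is new, unique, unknown or untested is made for them only; others in the source may bear on it.

Compound 1 `CC(Oc1ccc(Cl)cc1Cl)C(=O)NOCc1ccc(F)cc1`: 59000 nM
Compound 2 `CC(Oc1ccc(Cl)cc1Cl)C(=O)NCc1ccccc1`: 95000 nM
Compound 3 `CC(Oc1ccc(Cl)cc1Cl)C(=O)NCc1cccc(F)c1`: 27000 nM

In an ADME assay on CHO cells (Cricetulus griseus) for cytotoxicity, read by LDH release (a lower number here means a stronger inhibitor, a higher number a weaker inhibitor), compound 3 gives the lowest of the three numbers, and its gaps to the other two lie beyond the scatter. Compound 4 `CC(Oc1ccc(Cl)cc1Cl)C(=O)NCc1ccccc1F` carries 2-fluorophenyl in place of 3-fluorophenyl on a saturated chain carbon bound to an amide-type nitrogen. For the measured compounds named here, only one measured step bears on this, the modest 3.5-fold lower number from compound 2 to compound 3 (0.55 log units; beyond the scatter), which added the fluoro group. Going by the values given here, no measured step shows what changing the fluorophenyl group alone does, so only a small step is expected, with a slight lean towards a higher number and probably within the scatter. The expected change is a 1.3-fold higher number from compound 3 to compound 4 (0.11 log units; within the scatter). For compound 4 the estimated value is 35000 nM, with an expected range from 16000 nM to 85000 nM.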

Compound 4, half-maximal inhibitory concentration: 47000 nM
Beside the measured number, compound 4's estimate is 1.3-fold (0.13 log units) below it; the range from low to high includes it.
By their numbers in this assay, from the lowest: compounds 3, 4, 1 and 2 (each within the scatter of the next, the first and the last beyond it).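

In this assay, 2-fluorophenyl in place of 3-fluorophenyl gives a 1.7-fold higher number from compound 3 to compound 4 (0.24 log units; within the scatter) and so leaves the two groups not told apart. Fluoro in place of hydrogen on an aromatic carbon gives a 2.0-fold lower number from compound 2 to compound 4 (0.31 log units; beyond the scatter) as well, so the lower number seen with 3-fluorophenyl also appears with 2-fluorophenyl, though the step is modest. No evidence on hand accounts for either step.

The compounds shown leave open how a chloro, methoxy or carboxylic acid group would compare with fluoro on this ring.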